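The source may report more compounds than this note shows. Statements on the series, on what has been measured and on what is new or still open speak of the compounds shown alone.

Measured so far in a functional assay on BGC-823 cells (Homo sapiens) for antiproliferative activity, read by MTT assay; a lower number here means a stronger inhibitor, a higher number a weaker inhibitor:
Compound 1 `CCCCSc1ncnc2ccc(I)cc12`: 29000 nM
Compound 2 `C=CCSc1ncnc2ccc(I)cc12`: 33200 nM

Within the data shown here, compound 2 stands level with compound 1 on these numbers, since the only measured step is a 1.1-fold higher number from compound 1 to compound 2 (0.06 log units; within the scatter). That step changes the chain and leaves the shared core alone. Compound 3 `C=CCSc1ncnc2ccccc12` keeps the chain of compound 2 and alters the core instead: hydrogen in place of iodo on an aromatic carbon. Among the measured compounds shown here, no measured step touches that carbon, so the data give no direct guide to this change and no direction for it. The chain step, a 1.1-fold higher number from compound 1 to compound 2 (0.06 log units; within the scatter), bears on it only weakly. With nothing pointing either way, no step beyond the scatter is expected in this assay, though the uncertainty is wide. The expected step is a 1.2-fold higher number from compound 2 to compound 3 (0.08 log units; within the scatter). For compound 3 the estimated value is 40000 nM, with an expected range of 15000 nM to 110000 nM.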

Compound 3, half-maximal inhibitory concentration: 78100 nM
Compound 3: middle estimate off by 2.0-fold (0.29 log units), on the low side; the measured number falls inside the stated range.
By their numbers in this assay, from the lowest: compounds 1 and 2 (each within the scatter of the next); then compound 3.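

Swapping iodo for hydrogen on this aromatic carbon gives the first step in this assay that lies beyond the usual scatter, a 2.4-fold higher number from compound 2 to compound 3 (0.37 log units; beyond the scatter). Among these compounds, the only earlier step changed the chain and stayed within the scatter, so this is the first sign that the number responds to a change on the shared core, although the step is modest. With the chain of compound 2 in place, iodo at this carbon gives the lower number and so the stronger inhibition, but nothing available explains the difference.

Going by these compounds, only iodo and hydrogen appear at this carbon, so it remains open whether a bromo, chloro, methoxy or amino group would give a number nearer that of iodo or of hydrogen. On these data alone, it is also open whether removing iodo would produce a similar step with the chain of compound 1.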